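The source may report more compounds than this note shows. Statements on the series, on what has been measured and on what is new or still open speak of the compounds shown alone.

Measured compounds:
Compound 1, `COCCC(=O)NCCCNc1nc(Nc2cccc(F)c2)ncc1Br`, in an assay on isolated protein for inhibition of serine/threonine-protein kinase TBK1 (Homo sapiens) (on this read-out higher numbers stand for weaker inhibition and lower numbers for stronger inhibition), gives 60 nM.
Compound 2, `Cc1nn(C)c2cc(Nc3ncc(C4CC4)c(NCCCNC(=O)C4CCC4)n3)ccc12`, in this assay gives 7 nM.
Compound 3, `CN(C)Cc1ccc(Nc2ncc(C3CC3)c(NCCCNC(=O)C3CCC3)n2)cc1`, in this assay gives 6 nM.

Compound 1 carries the highest number of the three; compound 2 and compound 3 both sit lower, and both gaps to compound 1 lie beyond the scatter. Compound 1 therefore marks the weak end of what has been measured in this series.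

Compound 4, `O=C(NCCCNc1nc(Nc2cccc(F)c2)ncc1Br)c1cccs1`, is the next candidate. It differs from compound 1 in one place only: thiophen-2-yl in place of 2-methoxyethyl on a carbonyl carbon. Going by the values given here, no measured pair shows this exchange, so its size cannot be read from the data; the shared core is unchanged. For compound 4 the expected step is a 1.5-fold lower number from compound 1 to compound 4 (0.18 log units; within the scatter), a small move toward stronger inhibition, not clearly beyond the scatter. Compound 4 is estimated at 40 nM, with a range from 12 nM to 150 nM.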

Compound 4, half-maximal inhibitory concentration: 9 nM
Compound 4: the middle estimate sits 4.4-fold (0.65 log units) above what was measured, outside the stated range (below it).
By their numbers in this assay, from the lowest: compounds 3, 2 and 4 (each within the scatter of the next); then compound 1.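

On a carbonyl carbon whose other neighbour is an amide-type nitrogen, thiophen-2-yl in place of 2-methoxyethyl gives a 6.7-fold lower number from compound 1 to compound 4 (0.82 log units; beyond the scatter) in this assay. Going by these compounds alone, this is the first single-place step, and it shows that this substituent alone can move the number beyond the scatter while the shared core stays unchanged. No measurement at hand accounts for the step.

From the compounds shown here alone, whether the step follows the aromatic ring as such or its sulfur remains open. Phenyl or furan-2-yl on the same carbonyl carbon would bear on that question.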